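The source may report more compounds than this note shows. Statements on the series, on what has been measured and on what is new or still open speak of the compounds shown alone.

Measured compounds:
compound 1 `Fc1ccc(/C=N/c2sc3c(c2-c2nc4ccccc4s2)CCC3)cc1` — 372 ug/mL
compound 2 `C(=C/c1ccccc1)\C=N\c1sc2c(c1-c1nc3ccccc3s1)CCC2` — 100 ug/mL
compound 3 `Fc1ccc(/C=N/c2sc3c(c2-c2nc4ccccc4s2)CCCC3)cc1` — 277 ug/mL

In an ADME assay on HeLa cells (Homo sapiens) for cytotoxicity, read by MTT assay, with a stated time of 72 h (a lower number here means that less compound is tolerated, a higher number that more compound is tolerated), compound 3 gives the second highest of the three numbers. Its nearest neighbour is compound 1, whose value lies within the scatter of it, so no order between these two can be read. Compound 2 gives the lowest number of the set, and its distance from compound 3 is beyond the scatter.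

Compound 4 `Clc1ccccc1/C=N/c1sc2c(c1-c1nc3ccccc3s1)CCCC2` differs from compound 3 in one place: 2-chlorophenyl in place of 4-fluorophenyl on a carbon with a double bond to nitrogen. For the measured compounds named here, the only measured step, a 3.7-fold lower number from compound 1 to compound 2 (0.57 log units; beyond the scatter), concerns a different exchange on the same carbon, replacing the fluorinated ring by a chain-linked phenyl, and so bears only loosely on the present change, which keeps an aromatic ring of the same size and swaps one halogen for another at a different position of that ring. Going by the values given here, no measured pair isolates such a halogen swap. The expectation for this assay is therefore no step beyond the scatter, with a wide range to cover the uncertainty.

The step of a 1.1-fold lower number from compound 3 to compound 4 (0.04 log units; within the scatter) is expected to be small. Compound 4 is estimated at 250 ug/mL, with a range from 110 ug/mL to 550 ug/mL.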

Compound 4, half-maximal cytotoxic concentration: 407 ug/mL
Beside the measured number, compound 4's estimate is 1.6-fold (0.21 log units) below it, within the range that was stated.
By their numbers in this assay, from the lowest: compound 2; then compounds 3, 1 and 4 (each within the scatter of the next).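

In this assay the exchange of 4-fluorophenyl for 2-chlorophenyl gives a 1.5-fold higher number from compound 3 to compound 4 (0.17 log units; within the scatter) and so no readable change at this carbon with a double bond to nitrogen. The earlier exchange at the same kind of carbon, with 2-phenylethenyl entering, gave a 3.7-fold lower number from compound 1 to compound 2 (0.57 log units; beyond the scatter) on the core of compound 1, so this place can respond, while the swap between these two halogen-bearing phenyl groups on the core of compound 3 does not separate them. Nothing measured on these compounds explains the difference in size between the two steps.

As far as these compounds go, the halogen and its place on the ring change together in this pair, so the effect of each alone stays open. Also open, from the compounds shown here alone, is whether 2-phenylethenyl on the core of compound 3, or a phenyl group carrying an amine or a carboxylic acid at this carbon, would give a step beyond the scatter.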